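The source may hold more compounds than are shown below. What is called first, only, known or untested is meant among the compounds shown, and "the series" means these compounds.

Going by the values given here, in an ADME assay on HepG2 2.2.15 cells (Homo sapiens) for cytotoxicity, read by MTT assay (a higher number here means that more compound is tolerated, a lower number that less compound is tolerated), three esters of the shared core have numbers so far: compound 1 `C=C1CC[C@@H]2[C@](C)(COC(=O)/C=C/c3cccc(Cl)c3)[C@H](O)CC[C@@]2(C)[C@@H]1/C=C/C1=CCOC1=O` gives 147000 nM, compound 2 `C=C1CC[C@@H]2[C@](C)(COC(=O)c3ccc(OC)nc3)[C@H](O)CC[C@@]2(C)[C@@H]1/C=C/C1=CCOC1=O` gives 1340000 nM and compound 3 `C=C1CC[C@@H]2[C@](C)(COC(=O)c3ccco3)[C@H](O)CC[C@@]2(C)[C@@H]1/C=C/C1=CCOC1=O` gives 92000 nM. Compound 3 belongs to the low pair of these numbers, set apart only from the 6-methoxypyridin-3-yl ester. The data show a 1.6-fold lower number from compound 1 to compound 3 (0.20 log units; within the scatter), and also a 15-fold lower number from compound 2 to compound 3 (1.16 log units; beyond the scatter). Compound 4 `C=C1CC[C@@H]2[C@](C)(COC(=O)c3cccs3)[C@H](O)CC[C@@]2(C)[C@@H]1/C=C/C1=CCOC1=O` differs from it by thiophen-2-yl in place of furan-2-yl on a carbonyl carbon, with thiophen-2-yl in place of furan-2-yl on a carbonyl carbon. Among the compounds with values here, no measured step makes this exchange, so only the other changes at that carbonyl carbon bear on it. Both steps beyond the scatter, a 9.1-fold higher number from compound 1 to compound 2 (0.96 log units; beyond the scatter) and the large one above, involve the 6-methoxypyridin-3-yl group, while the exchange of 2-(3-chlorophenyl)ethenyl for furan-2-yl stayed within it. For this swap between two five-membered aromatic rings, no step beyond the scatter is therefore expected, and the estimate is a 1.1-fold higher number from compound 3 to compound 4 (0.04 log units; within the scatter). Compound 4 is expected at about 100000 nM, within an estimated range of 40000 nM to 280000 nM.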

Compound 4, half-maximal cytotoxic concentration: 557000 nM
Beside the measured number, compound 4's estimate is 5.6-fold (0.75 log units) below it; measured number outside the range, above it.
By their numbers in this assay, from the lowest: compounds 3 and 1 (each within the scatter of the next); then compound 4; then compound 2.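

In this assay, the exchange of two five-membered aromatic rings on a carbonyl carbon proves to matter, with a step beyond the scatter (a 6.1-fold higher number from compound 3 to compound 4 (0.78 log units; beyond the scatter)), so such steps at this position no longer all involve the 6-methoxypyridin-3-yl group. The thiophen-2-yl ester also separates from the other two esters, one on each side (a 3.8-fold higher number from compound 1 to compound 4 (0.58 log units; beyond the scatter); a 2.4-fold lower number from compound 2 to compound 4 (0.38 log units; beyond the scatter)), and it stands between the low pair and the 6-methoxypyridin-3-yl ester. No measurement here explains why a ring sulfur and a ring oxygen part so far.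

The compounds shown leave open whether this gap belongs to the ring hetero atom itself or to the thiophen-2-yl group as a whole. A thiophen-3-yl, a furan-3-yl or a thiazol-2-yl group on the same carbonyl carbon could separate these readings.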